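From compound 2 to compound 4, starting at a limit

The compounds below may be only part of what the source reports. "The series", "measured", "known", "first", "only" and "open" are said of these compounds alone.

In a functional assay on HEK293 cells (Homo sapiens) for cytotoxicity (on this read-out higher numbers stand for lower toxicity in this test and lower numbers for higher toxicity in this test), compound 2 (`COc1ccc([C@H]2CC(=O)N(c3cccc(C)c3)C2)cc1OC1CCCC1`) gives > 10000 nM as a limit and not a number. Compound 1 (`COc1ccc([C@H]2CC(=O)N(c3cccc(N)c3C)C2)cc1OC1CCCC1`) gives > 10000 nM as a limit too. Compound 3 (`COc1ccc([C@H]2CC(=O)N(c3ccccc3C(F)(F)F)C2)cc1OC1CCCC1`) gives > 10000 nM as a limit as well. Compound 2 therefore has no readable place among the three, and what has been measured comes down to the limit of > 10000 nM in this assay, at which 3 of the 3 values shown sit, and nothing finer.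

Compound 4 (`COc1ccc([C@H]2CC(=O)N(c3cccc(NCCCc4ccccc4)c3)C2)cc1OC1CCCC1`) keeps the shared core, and (3-phenylpropyl)amino in place of methyl on an aromatic carbon is all that separates it from compound 2. None of the three measured compounds carries a (3-phenylpropyl)amino group.

Both a step that the two limits leave unreadable from compound 1 to compound 2 and a step that the two limits leave unreadable from compound 2 to compound 3 bear on this aryl group on the amide-type nitrogen in a ring, yet neither gives a size to carry over. Among the measured compounds shown here, no step beyond the scatter can be expected from them, so the expectation is that compound 4 stays at the same limit in this assay with no readable change, although this new group has no measured precedent. The expected step is a number no higher from compound 2 to compound 4 (the limit leaves the size open) as estimated here. For compound 4 the estimate is 10000 nM with an expected range from 4000 nM to 25000 nM in all.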

Compound 4, half-maximal cytotoxic concentration: > 10000 nM
Compound 4 was reported as a limit (the forecaster's own chance of this, stated with the estimate: 75%); the middle value lies on the limit itself.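

In this assay compound 4 gives > 10000 nM, which is a limit and not a number. Among the compounds shown here, compound 2 also stands at a limit, so no step between compound 2 and compound 4 can be read. The compounds shown leave open whether any change to this aryl group alters the read-out, as all of them share one value: the limit of > 10000 nM in this assay, at which 4 of the 4 values shown sit.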